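The compounds below may be only part of what the source reports. "The series", "measured", "known", "first", "only" and "open" are said of these compounds alone.

Compounds measured so far in a functional assay on MGC-803 cells (Homo sapiens) for cytotoxicity, read by MTT assay, with a stated time of 72 h; a lower number here means a stronger inhibitor, a higher number a weaker inhibitor:

- compound 1 `O=C(CSC(=S)N[C@H]1CCOC1=O)Nc1ccc(C(=O)/C=C/c2ccc(F)cc2)cc1` — 45700 nM
- compound 2 `O=C(CSC(=S)N[C@H]1CCOC1=O)Nc1ccc(C(=O)/C=C/c2cccc(Cl)c2)cc1` — 15600 nM

For the measured compounds named here, of these two numbers, compound 2 shows the lower one; its only neighbour is compound 1, and the step of a 2.9-fold lower number from compound 1 to compound 2 (0.47 log units; beyond the scatter) lies beyond the scatter, so compound 2 stands as the stronger inhibitor of the pair in this assay.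

Compound 3 `O=C(CSC(=S)N[C@H]1CCOC1=O)Nc1ccc(C(=O)/C=C/c2ccc([N+](=O)[O-])cc2)cc1` has not yet been measured. It differs from compound 2 in one place: 4-nitrophenyl in place of 3-chlorophenyl on a double-bonded chain carbon bound to a double-bonded chain carbon. Going by the values given here, the only step that bears on this change is the one from compound 1 to compound 2, which also swapped the aryl ring on the same chain carbon and gave a 2.9-fold lower number from compound 1 to compound 2 (0.47 log units; beyond the scatter). Among the compounds with values here, that single step shows a ring swap at this position can move the number by a modest amount, but it gives no guide to the direction for a 4-nitrophenyl ring, since no measured compound carries one.

Compound 3 is therefore expected to land near compound 2, with a step of a 1.3-fold higher number from compound 2 to compound 3 (0.11 log units; within the scatter) and a wide range, the estimate being 20000 nM (between 6000 nM and 65000 nM).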

Compound 3, half-maximal inhibitory concentration: 29400 nM
Compound 3: the middle estimate sits 1.5-fold (0.17 log units) below what was measured; the measured number falls inside the stated range.
By their numbers in this assay, from the lowest: compounds 2, 3 and 1 (each within the scatter of the next, the first and the last beyond it).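

In this assay, 4-nitrophenyl in place of 3-chlorophenyl on a double-bonded chain carbon gives a 1.9-fold higher number from compound 2 to compound 3 (0.28 log units; within the scatter), and nitro in place of fluoro on an aromatic carbon gives a 1.6-fold lower number from compound 1 to compound 3 (0.19 log units; within the scatter). Both steps lie within the scatter, so the new ring cannot be separated from either earlier ring, even though those two rings differ beyond the scatter, with a 2.9-fold lower number from compound 1 to compound 2 (0.47 log units; beyond the scatter). The hydrogen-bond acceptors counted on the nitro group therefore come with no step beyond the scatter in this small set, and the difference between the 4-fluorophenyl and 3-chlorophenyl rings remains the only clear one at this position.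

The compounds shown leave open how a plain phenyl ring, or an aromatic ring carrying an amine, a carboxylic acid or a methoxy group, would read at this chain carbon. No further measurement shown bears on this result.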